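The source may report more compounds than this note shows. Statements on the series, on what has been measured and on what is new or still open speak of the compounds shown alone.

Working notes on the series. Three analogues with a shared core have numbers in a functional assay on MKN-45 cells (Homo sapiens) for cytotoxicity, read by MTT assay, with a stated time of 72 h (a lower number here means a stronger inhibitor, a higher number a weaker inhibitor), so far. Compound 1 `CN(C)CCn1cnnc1-c1cc(Oc2ccc(NC(=O)N/N=C/c3cccc(O)c3)cc2F)ccn1` gives 1370 nM in this assay. Compound 2 `CN(C)CCn1cnnc1-c1cc(Oc2ccc(NC(=O)N/N=C/c3ccc(F)cc3Cl)cc2F)ccn1` gives 870 nM in this assay. Compound 3 `Cc1cc(/C=N/NC(=O)Nc2ccc(Oc3ccnc(-c4nncn4CCN(C)C)c3)c(F)c2)cc(C)c1O` gives 1510 nM in this assay. Compound 2 carries the lowest of the three numbers, though neither step from it leaves the scatter: the step of a 1.6-fold lower number from compound 1 to compound 2 (0.20 log units; within the scatter) and the step of a 1.7-fold higher number from compound 2 to compound 3 (0.24 log units; within the scatter) are both small, and the step of a 1.1-fold higher number from compound 1 to compound 3 (0.04 log units; within the scatter) likewise sits within the scatter.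

The next compound, compound 4 `COc1cc(/C=N/NC(=O)Nc2ccc(Oc3ccnc(-c4nncn4CCN(C)C)c3)c(F)c2)ccc1O`, has not been measured in this assay. Its change from compound 2 is 4-hydroxy-3-methoxyphenyl in place of 2-chloro-4-fluorophenyl on a carbon with a double bond to nitrogen. The two measured steps that bear on it both exchange the group on the carbon with a double bond to nitrogen and both end in a hydroxy-bearing phenyl; the step of a 1.6-fold lower number from compound 1 to compound 2 (0.20 log units; within the scatter) read in reverse and the step of a 1.7-fold higher number from compound 2 to compound 3 (0.24 log units; within the scatter) point the same way, each within the scatter. Going by the values given here, no step in the set moved beyond the scatter, so for compound 4 a small rise in the number, if any, is expected, with an estimated step of a 1.6-fold higher number from compound 2 to compound 4 (0.21 log units; within the scatter). Compound 4 is therefore expected to give about 1400 nM in this assay, within a range of 700 nM to 2800 nM.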

Compound 4, half-maximal inhibitory concentration: 3780 nM
Estimate against measurement, compound 4: 2.7-fold (0.43 log units) below; measured number above the stated range.
By their numbers in this assay, from the lowest: compounds 2, 1 and 3 (each within the scatter of the next); then compound 4.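

Going by these compounds alone, at the group on the carbon with a double bond to nitrogen, 4-hydroxy-3-methoxyphenyl gives the first change in this assay to leave the scatter, with a 4.3-fold higher number from compound 2 to compound 4 (0.64 log units; beyond the scatter) and with a 2.8-fold higher number from compound 1 to compound 4 (0.44 log units; beyond the scatter) and also a 2.5-fold higher number from compound 3 to compound 4 (0.40 log units; beyond the scatter) as modest steps in the same direction. Compound 4 thus carries the weakest number of the four, and a hydroxy group on this phenyl does not by itself account for that, since compound 1 and compound 3 also carry one and stay within the scatter of compound 2. No measured data on the series bear on the reason for this rise.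

Still open, going by these compounds, is whether the rise follows the methoxy group alone or its pairing with the hydroxy group, which a methoxyphenyl without the hydroxy group or a dimethoxyphenyl at this place would separate. Also open, on these data alone, is how an amine or a carboxylic acid on this phenyl would move the number, and whether the order of these four compounds holds in any cell line other than the one tested here.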